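The source may report more compounds than this note shows. Statements on the series, on what has been measured and on what is new or still open speak of the compounds shown alone.

Compound 1 `CN(C)C(=O)N1Cc2ccccc2C(c2cccc(O)c2)C1` is the parent of this small set, yet in a functional assay on A2780 cells (Homo sapiens) for antiproliferative activity (a lower number here means a stronger inhibitor, a higher number a weaker inhibitor), compound 1 gives "not determined" (no result reported), so no single number fixes where it stands. Within the data shown here, the only measured relative is compound 2 `CN(C)C(=O)N1Cc2cc(I)ccc2C(c2cccc(O)c2)C1`, which carries iodine on the same ring; in this assay compound 2 gives 363 nM, and that value is the sole anchor for the series. Compound 3 `CCc1cccc2c1CN(C(=O)N(C)C)CC2c1cccc(O)c1` has not been measured. It differs from compound 1 by ethyl in place of hydrogen on an aromatic carbon. Among the measured compounds shown here, no step between measured compounds shows this change, so its size is unknown; a shift of modest size in this assay seems likely, and a change that stays within the usual scatter cannot be excluded. Compound 3 is expected to give about 1000 nM in this assay, with a likely range from 200 nM to 5000 nM. That guess leans on compound 2, whose result of 363 nM is the only measured point nearby.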

Compound 3, half-maximal inhibitory concentration: 186 nM
The estimate for compound 3 lay 5.4-fold (0.73 log units) above the measured number; measured number below the stated range.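

In this assay, among these compounds, compound 1 gives "not determined" (no result reported), so no step from it to compound 3 can be read. No other data shown here bear on the result for compound 3. The compounds shown leave open how far ethyl in place of hydrogen shifts activity in this assay.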